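The source may report more compounds than this note shows. Statements on the series, on what has been measured and on what is new or still open speak of the compounds shown alone.

Working notes on the series. The starting point is compound 1 `O=C(Nc1cccc(-c2ccc(F)cc2)c1)C(Cl)Cl`. In a functional assay on NCI-H460 cells (Homo sapiens) for cytotoxicity, read by MTT assay, with a stated time of 68 h (a lower number here means a stronger inhibitor, a higher number a weaker inhibitor), compound 1 gives > 50000 nM, which is a limit of the assay and not a number. Compound 3 `O=C(Nc1cccc(-c2ccccc2Cl)c1)C(Cl)Cl`, in this assay, also gives > 50000 nM, again a limit rather than a number. Among the measured compounds shown here, the one member with a measured number is compound 2 `CCOc1cccc(-c2cc(NC(=O)C(Cl)Cl)cc(-c3cccc(OCC)c3)c2)c1`, which in this assay gives 4950 nM. Compound 1 therefore sits at the limit of > 50000 nM in this assay, at which 2 of the 3 values shown sit, while compound 2 alone lies inside the measurable range of this assay.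

The next compound is compound 4 `Cc1ccc(-c2cccc(NC(=O)C(Cl)Cl)c2)cc1`. It differs from compound 1 by methyl in place of fluoro on an aromatic carbon. For the measured compounds named here, no measured pair in this set isolates such a change, and no direction can be read from the values shown, since compound 1 has no number to move from. For compound 4 the expected step is a number no higher from compound 1 to compound 4 (the limit leaves the size open), in effect none beyond the scatter, with another limit the most likely outcome. Compound 4 is accordingly estimated at 50000 nM in this assay, with a range from 20000 nM to 100000 nM.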

Compound 4, half-maximal inhibitory concentration: 8000 nM
Beside the measured number, compound 4's estimate is 6.3-fold (0.80 log units) above it, and the stated range ends above it.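

With methyl in place of fluoro on an aromatic carbon, para to a large group, the series shows an at least 6.2-fold lower number from compound 1 to compound 4 (0.79 log units; beyond the scatter) in this assay, so this position can move a compound onto a measured number. Compound 1 gives > 50000 nM, which is a limit of the assay and not a number, so the step has a lower bound and no upper one. The earlier compounds gave no step at this position, and compound 4 now stands off the limit that holds the other members with a single aromatic substituent: the limit of > 50000 nM in this assay, at which 2 of the 4 values shown sit.

One pair cannot separate a contribution of methyl from the loss of fluoro, and it gives no cause for the step. As far as these compounds go, how an amine, a carboxylic acid, or a longer chain such as propyl would read at this position remains open.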